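Working notes: lipophilicity across compounds 1 to 4

A few compounds are considered here, and "the series" means these few. Any claim that something is new, unique, unknown or untested is made for them only; others in the source may bear on it.

Measured so far in a physicochemical assay for lipophilicity; on this read-out lower numbers stand for lower lipophilicity and higher numbers for higher lipophilicity:
compound 1 `CCOC(=O)/C=C(C)/C=C/CC(C)CCCC(C)(C)OC` gives 5.54
compound 2 `COC(C)(C)CCCC(C)C/C=C/C(C)=C/C(=O)OC1CC1` gives 5.71
compound 3 `CCOC(=O)/C=C(C)/C=C/CC(C)CCC(OC)C(C)(C)OC` gives 4.34

Compound 1 stands second highest of the three; its nearest neighbour is compound 2, with a number 0.17 log units higher from compound 1 to compound 2 (within the scatter), and its furthest is compound 3, with a number 1.20 log units lower from compound 1 to compound 3 (beyond the scatter).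

Compound 4 `CCOC(=O)/C=C(C)/C=C/CC(C)CCC=C(C)C` is not yet measured. It differs from compound 1 by 2-methylprop-1-en-1-yl in place of 2-methoxy-2-methylpropyl on a saturated chain carbon, four bonds along the chain from a double-bonded chain carbon. The step from compound 1 to compound 3 is the one that bears on this change, since a methoxy enters there and a methoxy leaves here, along with a shorter chain fragment entering. A rise beyond the scatter is therefore expected, though smaller than that step, and compound 4 is expected at 6, between 5.5 and 6.5, meaning an expected a number 0.46 log units higher from compound 1 to compound 4 (beyond the scatter).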

Compound 4, partition coefficient: 6.19
Beside the measured number, compound 4's estimate is 0.19 log units below it, within the range that was stated.
By their numbers in this assay, from the lowest: compound 3; then compounds 1 and 2 (each within the scatter of the next); then compound 4.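

At the saturated chain carbon, four bonds along the chain from a double-bonded chain carbon, 2-methylprop-1-en-1-yl in place of 2-methoxy-2-methylpropyl gives a number 0.65 log units higher from compound 1 to compound 4 (beyond the scatter) in this assay. For the compounds shown here, this is the first step that rises beyond the scatter, since the earlier steps either stay within it or fall. No measurement on hand accounts for this rise.

Going by these compounds alone, the single step removes the methoxy and introduces the double bond together, so their separate contributions remain open. On these data alone, how an amine or a carboxylic acid at this position would read in this assay also remains open.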